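This account rests on a few compounds, and the source may have more. Where it says the series, first, only, none or still open, it means among the compounds named here.

Two compounds share the same core here, compound 1 (`Cn1c[n+](Cc2ccccc2)c2/c(=N/OC(C)(C)C)[nH]cnc21`) and compound 2 (`CO/N=c1\[nH]cnc2c1[n+](C/C=C(\C)CCC=C(C)C)cn2C`). In a functional assay on U-937/GTB cells (Homo sapiens) for cytotoxicity (a higher number here means a weaker inhibitor, a lower number a stronger inhibitor), compound 1 has the entry "not determined" (no result reported), so it offers no number for comparison. Among the compounds with values here, compound 2 gives 17500 nM, the only number available, and so it cannot yet be ranked against anything.

Compound 3 (`CO/N=c1\[nH]cnc2c1[n+](C/C=C(\C)CC/C=C(/C)CCC=C(C)C)cn2C`) keeps the core of compound 2 and extends its chain: 3-methylbut-2-en-1-yl in place of hydrogen on a saturated chain carbon bound to a double-bonded chain carbon. In words, 3-methylbut-2-en-1-yl replaces hydrogen on a saturated chain carbon bound to a double-bonded chain carbon.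

Within the data shown here, no pair of measured compounds shows what a change like this does, so the forecast is uncertain and rests on the structural change alone. The expectation is a moderate move towards a lower number in this assay, meaning a stronger inhibitor, although a result within the usual scatter would be no surprise. Compound 2, at 17500 nM, is the single anchor for this expectation. The estimated change is a 3.5-fold lower number from compound 2 to compound 3 (0.54 log units; beyond the scatter). For compound 3 the expected value is 5000 nM, with an estimated range from 1800 nM to 14000 nM.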

Compound 3, half-maximal inhibitory concentration: 1400 nM
Compound 3: the middle estimate sits 3.6-fold (0.55 log units) above what was measured, and the stated range ends above it.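

In this assay, within the data shown here, the added 3-methylbut-2-en-1-yl, placed on a saturated chain carbon bound to a double-bonded chain carbon, gives a 13-fold lower number from compound 2 to compound 3 (1.10 log units; beyond the scatter) and this large step is the first measured sign that the chain on the shared core matters for the read-out. Until now compound 2 stood alone with a number and compound 1 had no result, so nothing showed whether changing this chain would move the value at all. The step shows that this position accepts a clearly larger chain and that the larger chain goes with a stronger inhibitor, although this rests on a single pair of compounds and is not yet a trend.

Going by these compounds, it remains open whether a still longer chain would lower the number further or whether the gain stops at this length, and whether an amine or a carboxylic acid at the far end of the chain would keep the effect. Nothing shown here explains why the number falls so far.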